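Swapping Cyclohexylsulfonyl for Methylsulfonyl in Two Related Series

A few compounds are considered here, and "the series" means these few. Any claim that something is new, unique, unknown or untested is made for them only; others in the source may bear on it.

Two pairs of compounds share one structural change. Compound 1 `C=C(CC)C(=O)c1ccc(OCC(=O)N2CCN(S(=O)(=O)C3CCCCC3)CC2)c(Cl)c1Cl` and compound 2 `C=C(CC)C(=O)c1ccc(OCC(=O)N2CCN(S(C)(=O)=O)CC2)c(Cl)c1Cl` differ in this way: methyl in place of cyclohexyl on a sulfonyl sulfur. In a functional assay on HL-60 cells (Homo sapiens) for cytotoxicity, read by luminescence (a higher number here means a weaker inhibitor, a lower number a stronger inhibitor), compound 1 gives 2320 nM, and compound 2 gives 3390 nM. The step of a 1.5-fold higher number from compound 1 to compound 2 (0.16 log units; within the scatter) is small, so the two values cannot be told apart.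

Compound 3 `C=C(CC)C(=O)c1ccc(OCC(=O)NC2CCN(S(=O)(=O)C3CCCCC3)CC2)c(Cl)c1Cl` carries a different core; the difference between the core of compound 1 and the core of compound 3 is not broken down here. In this assay compound 3 gives 2940 nM. Compound 4 `C=C(CC)C(=O)c1ccc(OCC(=O)NC2CCN(S(C)(=O)=O)CC2)c(Cl)c1Cl` has not yet been measured; it differs from compound 3 as follows: methyl in place of cyclohexyl on a sulfonyl sulfur. The place of the change is the same word for word in both pairs, so this is the same change.

Since the step from compound 1 to compound 2 stayed within the scatter, the step from compound 3 to compound 4 is expected to be similarly small, about a 1.4-fold higher number from compound 3 to compound 4 (0.14 log units; within the scatter). Compound 4 is therefore estimated at 4100 nM, with a likely range from 2000 nM to 8500 nM.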

Compound 4, half-maximal inhibitory concentration: 3330 nM
Compound 4: middle estimate off by 1.2-fold (0.09 log units), on the high side; the measured number falls inside the stated range.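

In this assay the new step is a 1.1-fold higher number from compound 3 to compound 4 (0.05 log units; within the scatter), so these two values cannot be told apart. Set beside the earlier pair, the swap from cyclohexyl to methyl gives the same picture on both cores: the same change on two cores in this assay, a 1.5-fold higher number (0.16 log units; within the scatter) from compound 1 to compound 2 and a 1.1-fold higher number (0.05 log units; within the scatter) from compound 3 to compound 4, 1.3-fold (0.11 log units) apart, within the scatter of two such steps. Going by these compounds alone, this shows that, on these two cores, a large carbon ring on the sulfonyl sulfur can give way to a single methyl with no step that can be read in this cytotoxicity measurement, but it does not show that a real effect carries from one core to another, since neither step stands clear of the scatter and two flat steps agreeing is a weak test.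

On these data alone, what a phenyl ring, an amine or a longer carbon chain on the same sulfonyl sulfur would give remains open. So does whether the swap would stay as quiet on a core other than these two, or in a cell type other than the one used here.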